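The compounds below may be only part of what the source reports. "The series", "measured", "known", "first", "only" and "open" are said of these compounds alone.

Compound 1 `CC(C)(C)c1ccc(NC(=O)CCCCl)cc1` carries a (3-chloropropyl)carbonyl amide. In a functional assay on HT-29 cells (Homo sapiens) for antiproliferative activity, with a stated time of 48 h (on this read-out higher numbers stand for weaker inhibition and lower numbers for stronger inhibition), compound 1 gives only a limit, > 100000 nM. Compound 2 `CCCCC(O)c1cccc(NC(=O)CCCCl)c1` likewise gives only a limit in this assay, > 100000 nM. Two of the three numbers shown are therefore limits, namely (the limit of > 100000 nM in this assay, at which 2 of the 3 values shown sit). Compound 3 `C=CC(=O)Nc1ccc(C(C)(C)C)cc1` gives 24000 nM in this assay. The change vinyl in place of 3-chloropropyl on a carbonyl carbon thus produces an at least 4.1-fold lower number from compound 1 to compound 3 (0.61 log units; beyond the scatter). How the core of compound 1 differs from that of compound 2 is not broken down here. Compound 4 `C=CC(=O)Nc1cccc(C(O)CCCC)c1` is compound 2 with the same change, (vinyl in place of 3-chloropropyl on a carbonyl carbon), at the same place. For compound 4 the step from compound 2 is expected to be an at least 3.3-fold lower number from compound 2 to compound 4 (0.52 log units; beyond the scatter), resting on an at least 4.1-fold lower number from compound 1 to compound 3 (0.61 log units; beyond the scatter); since compound 2 sits at a limit, only a lower bound of the step can be inferred. Compound 4 is estimated at 30000 nM, between 8000 nM and 100000 nM.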

Compound 4, half-maximal inhibitory concentration: > 100000 nM
Compound 4: no number, only a limit (the forecaster's own chance of this, stated with the estimate: 25%); middle value at least 3.3-fold (0.52 log units) from the limit.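

Among the compounds shown here, compound 2 and compound 4 both give only a limit, so no step between them can be read. From the compounds shown here alone, whether vinyl in place of 3-chloropropyl on a carbonyl carbon lowers the number on the core of compound 2, as it does from compound 1 to compound 3, stays open.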